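The compounds below may be only part of what the source reports. "The series", "measured", "known", "first", "only" and "open" are said of these compounds alone.

Working notes on the series. In an assay on CHO-K1 cells for displacement of a labelled ligand from prostaglandin E2 receptor EP1 subtype (Homo sapiens) (a lower number here means a stronger inhibitor, a higher number a weaker inhibitor), compound 1 `CC(=O)Nc1cc(C)n(Cc2cc(Cl)ccc2OCc2ccccc2)n1` gives 316 nM. Compound 2 `Cc1cc(NC(=O)C(C)C)nn1Cc1cc(Cl)ccc1OCc1ccccc1` gives 25.1 nM in this assay, and compound 3 `Cc1cc(NC(=O)C2CCCCC2)nn1Cc1cc(Cl)ccc1OCC(C)C` gives 31.6 nM. For the measured compounds named here, the only single-point step measured so far is a 13-fold lower number from compound 1 to compound 2 (1.10 log units; beyond the scatter). On these three numbers compound 2 stands lowest: compound 3 sits within the scatter of it, while compound 1 lies well beyond the scatter above it.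

Compound 4 `CCOC(=O)Nc1cc(C)n(Cc2cc(Cl)ccc2OCc2ccccc2)n1` is not yet measured. It differs from compound 2 by ethoxy in place of isopropyl on a carbonyl carbon; cut one bond further out, the change reads isopropylcarbonyl to ethoxycarbonyl, on the carbonyl carbon whose other neighbour is the amide-type nitrogen.

The step from compound 1 to compound 2 bears on this position: it shows that what sits on this carbonyl carbon moves the number strongly, as a 13-fold lower number from compound 1 to compound 2 (1.10 log units; beyond the scatter) was large. Going by the values given here, nothing measured so far, however, carries an oxygen in place of carbon at this spot, so no direct precedent exists. The entering ethoxy matches the leaving isopropyl in heavy-atom count but adds one hydrogen-bond acceptor. A moderate rise in the number is therefore expected for compound 4, possibly still within the scatter, as a 2.5-fold higher number from compound 2 to compound 4 (0.40 log units; beyond the scatter). The estimate for compound 4 is 63 nM, with a range from 20 nM to 200 nM.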

Compound 4, half-maximal inhibitory concentration: 79.4 nM
Beside the measured number, compound 4's estimate is 1.3-fold (0.10 log units) below it; the range from low to high includes it.
By their numbers in this assay, from the lowest: compounds 2 and 3 (each within the scatter of the next); then compound 4; then compound 1.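

In this assay, ethoxy in place of isopropyl on the carbonyl carbon, with the heavy-atom count unchanged and one hydrogen-bond acceptor added, gives a 3.2-fold higher number from compound 2 to compound 4 (0.50 log units; beyond the scatter), so this position responds to oxygen in place of carbon even when the number of heavy atoms stays the same. Against the methyl group, the same ethoxy gives a 4.0-fold lower number from compound 1 to compound 4 (0.60 log units; beyond the scatter), which places ethoxy between the two carbon groups: from the lowest number to the highest, the order at this carbonyl carbon is isopropyl, ethoxy, methyl, and each listed step is beyond the scatter. Nothing available on these compounds explains why ethoxy falls at this point in the order.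

These three groups leave open whether a longer chain on the oxygen, such as butoxy, or a nitrogen at the same spot, as in a dimethylamino group, would track with ethoxy or with isopropyl. Compound 3 differs from compound 2 and compound 4 in more than one place, so it cannot settle how the ethoxy change behaves alongside other groups on the shared core.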